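Cyano in place of acetamido: working notes on cytotoxicity

The source may hold more compounds than are shown below. What is called first, only, known or untested is meant among the compounds shown, and "the series" means these compounds.

Measured so far:
compound 2 `COc1ccc(/C=C\C(=O)O)c(OCc2cn(-c3ccc(NC(C)=O)cc3)nn2)c1CC=C(C)C` — 45700 nM
compound 3 `COc1ccc(/C=C\C(=O)O)c(OCc2cn(-c3ccc(CO)cc3)nn2)c1CC=C(C)C` — 27100 nM
compound 1 `COc1ccc(/C=C\C(=O)O)c(OCc2cn(-c3ccccc3C(=O)N3CCC(O)C3)nn2)c1CC=C(C)C` — "not determined" (no result reported)

In a functional assay on NCI-H322 cells (Homo sapiens) for cytotoxicity, read by MTT assay, with a stated time of 24 h (on this read-out lower numbers stand for stronger inhibition and higher numbers for weaker inhibition), compound 2 gives 45700 nM, the highest of the two numbers, and compound 3 gives 27100 nM; the step of a 1.7-fold lower number from compound 2 to compound 3 (0.23 log units; within the scatter) lies within the scatter. For compound 1 this assay reports nothing.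

Compound 4 `COc1ccc(/C=C\C(=O)O)c(OCc2cn(-c3ccc(C#N)cc3)nn2)c1CC=C(C)C` differs from compound 2 by cyano in place of acetamido on an aromatic carbon. Among the measured compounds shown here, the only step that bears on it is the one from compound 2 to compound 3, another replacement of the acetamido at the same aromatic carbon, and that step stayed within the scatter. No step beyond the scatter is therefore expected in this assay. Compound 4 is estimated at 35000 nM, range 12000 nM to 90000 nM, which means an expected step of a 1.3-fold lower number from compound 2 to compound 4 (0.12 log units; within the scatter).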

Compound 4, half-maximal inhibitory concentration: 18600 nM
Compound 4: the middle estimate sits 1.9-fold (0.27 log units) above what was measured, within the range that was stated.
By their numbers in this assay, from the lowest: compounds 4, 3 and 2 (each within the scatter of the next, the first and the last beyond it).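

In this assay, replacing acetamido on this aromatic carbon, para to a large group, can move the number beyond the scatter (a 2.5-fold lower number from compound 2 to compound 4 (0.39 log units; beyond the scatter)), which the hydroxymethyl step (a 1.7-fold lower number from compound 2 to compound 3 (0.23 log units; within the scatter)) did not do. Cyano and hydroxymethyl remain indistinguishable here (a 1.5-fold lower number from compound 3 to compound 4 (0.16 log units; within the scatter)), so the shift beyond the scatter belongs to the cyano compound alone and does not separate the two replacements. No available evidence bears on the reason for this step.

The compounds shown leave open how an amine, a carboxylic acid or a longer chain on this carbon would read in this assay. They also leave open whether the step from acetamido to cyano would hold with any other change to the shared core.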